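Swapping a Nitro for a Methoxybenzyl on the Core

The source may report more compounds than this note shows. Statements on the series, on what has been measured and on what is new or still open speak of the compounds shown alone.

Measured compounds:
compound 1 `COc1cc(Cn2cc(COc3cccc(/C=C4/C(=O)Nc5ccccc54)c3)nn2)cc(OC)c1` — 25600 nM
compound 2 `O=C1Nc2ccc([N+](=O)[O-])cc2/C1=C\c1cccc(OCc2cn(Cc3ccccc3)nn2)c1` — "not determined" (no result reported)

In a functional assay on DU-145 cells (Homo sapiens) for inhibition, read by MTT assay, with a stated time of 48 h (a higher number here means a weaker inhibitor, a lower number a stronger inhibitor), compound 1 gives 25600 nM, a weak result. For compound 2 the assay gives "not determined" (no result reported), so compound 2 stands nowhere on the scale and there is no value to compare with. Compound 3 `COc1ccc(Cc2ccc3c(c2)/C(=C\c2cccc(OCc4cn(Cc5ccccc5)nn4)c2)C(=O)N3)cc1` differs from compound 2 by 4-methoxybenzyl in place of nitro on an aromatic carbon. For the measured compounds named here, no step between two measured compounds is available to show what such a change does, so neither its direction nor its size can be read from the data. Going by the values given here, the only anchor is compound 1, which shares the core and the triazole link and sits at a weak level in this assay. A step in either direction would not surprise, and none beyond the scatter is the safest reading. Compound 3 is therefore expected to come out near 15000 nM, in a range from 3000 nM to 60000 nM.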

Compound 3, half-maximal inhibitory concentration: > 50000 nM
Compound 3 ended at the assay's limit; the forecaster's own chance of this, stated with the estimate: 25%; middle value at least 3.3-fold (0.52 log units) from the limit.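

In this assay compound 3 gives > 50000 nM, which is a limit of the assay and not a number. For the compounds shown here, compound 2 has no value, and no step to compound 3 can be read. On these data alone, what replacing nitro with 4-methoxybenzyl does to potency on these cells stays open.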